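A few compounds are considered here, and "the series" means these few. Any claim that something is new, unique, unknown or untested is made for them only; others in the source may bear on it.

Two macrocycles open this account. Compound 1, with the structure `COc1c2cc(c(OC)c1O)Oc1ccc(cc1)[C@@H](O)C[C@@H](O)/C=C/C=C\2`, and compound 2, with the structure `O=C1CCc2ccc(O)c(c2)-c2cc(ccc2O)C[C@H](O)C[C@H]1O`, share a macrocyclic core bearing diol groups, and both were tested in a functional assay on SAOS-2 cells (Homo sapiens) for cytotoxicity, read by spectrophotometry and crystal violet staining, with a stated time of 48 h; a lower number here means that less compound is needed, a higher number that more compound is needed for the effect. In this assay compound 1 reaches only the limit of the measurement, > 150000 nM, and no number. Compound 2 likewise sits at the limit of this assay, > 150000 nM, again a limit rather than a number. Where compound 2 stands is therefore fixed only by the limit of > 150000 nM in this assay, at which 2 of the 2 values shown sit, and nothing in the two values shown separates the two compounds from each other.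

Compound 3, with the structure `O=C1CCc2ccc(O)c(c2)-c2cc(ccc2O)C[C@H](O[C@@H]2O[C@H](CO)[C@H](O)[C@@H](O)[C@H]2O)C[C@H]1O`, differs from compound 2 by a group of 11 heavy atoms (6 carbon, 5 oxygen; one six-membered non-aromatic ring with 1 hetero atom) in place of a hydrogen atom, on an oxygen on a saturated carbon. Among the measured compounds shown here, no step between two measured compounds is available to gauge what such a change does in this assay; the only information is that compound 2 already reaches the limit. The expectation is therefore that the step that the limit leaves unreadable from compound 2 to compound 3 is none beyond the usual scatter. Compound 3 is accordingly expected to give about 200000 nM in this assay, within a range from 50000 nM to 800000 nM, most likely reported again as a limit only.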

Compound 3, half-maximal effective concentration: > 150000 nM
Compound 3: only a limit was reported; the forecaster's own chance of this, stated with the estimate: 85%; the middle value lies beyond the limit too.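

In this assay compound 3 gives > 150000 nM and so reaches a limit, not a number. Compound 2 also stands at a limit, so the step from compound 2 to compound 3 cannot be read: the limit of > 150000 nM in this assay, at which 3 of the 3 values shown sit. The compounds shown leave open whether the group of 11 heavy atoms in place of a hydrogen atom changes anything in this assay at all.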